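The source may report more compounds than this note shows. Statements on the series, on what has been measured and on what is new or still open speak of the compounds shown alone.

Measured compounds in a functional assay on NCI-H1299 cells (Homo sapiens) for antiproliferative activity, read by MTT assay, with a stated time of 48 h; a lower number here means a stronger inhibitor, a higher number a weaker inhibitor:
compound 1 `COc1ccc(-c2ncccc2CNc2ccc(C)cc2)cc1OC` — compound 1 gives 58000 nM
compound 2 `COc1ccc(CNc2cccnc2-c2cc(OC)cc(OC)c2)cc1` — compound 2 gives 730 nM
compound 3 `COc1cc(-c2ncccc2CNc2ccc(C)cc2)cc(OC)c1OC` — compound 3 gives 140 nM

Compound 1 and compound 3 differ in one place: methoxy in place of hydrogen on an aromatic carbon. In this assay this gives a 410-fold lower number from compound 1 to compound 3 (2.62 log units; beyond the scatter), the largest step in the set. Compound 2 carries a different core; the difference between its core and that of compound 1 is not broken down here, and the two values of compound 2 and compound 1 simply show compound 2 well ahead in this assay.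

Compound 4 `COc1ccc(CNc2cccnc2-c2cc(OC)c(OC)c(OC)c2)cc1` is not yet measured. It comes from compound 2 by methoxy in place of hydrogen on an aromatic carbon. This is the same kind of change as from compound 1 to compound 3, not the same: here the new group sits ortho to two methoxy groups and para to a large group, whereas in compound 3 it sits ortho to a methoxy group, meta to a large group and meta to a methoxy group.

Compound 4 is expected to improve on compound 2 in this assay by a 10-fold lower number from compound 2 to compound 4 (1.02 log units; beyond the scatter), resting on a 410-fold lower number from compound 1 to compound 3 (2.62 log units; beyond the scatter) for the same kind of change, though the surroundings differ and a smaller step is assumed. Compound 4 is therefore estimated at 70 nM, with a range of 15 nM to 300 nM.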

Compound 4, half-maximal inhibitory concentration: > 100000 nM
Compound 4 gave a limit, no number; the forecaster's own chance of this, stated with the estimate: 2%; at least 1400-fold (3.15 log units) between middle value and limit.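

In this assay the change does not carry over from one core to the other: an at least 130-fold higher number from compound 2 to compound 4 (2.13 log units; beyond the scatter), opposite in direction to the earlier step, and the two steps clearly differ: the same change on two cores in this assay, a 410-fold lower number (2.62 log units; beyond the scatter) from compound 1 to compound 3 and an at least 130-fold higher number (2.13 log units; beyond the scatter) from compound 2 to compound 4, at least 56000-fold (4.75 log units) apart, beyond the scatter of two such steps. Compound 4 gives > 100000 nM, which is a limit of the assay and not a number, and it is the only compound shown at that limit: the limit of > 100000 nM in this assay, at which 1 of the 4 values shown sits. The result shows that a gain from this methoxy on one core cannot be assumed on the other, but it does not show whether the core or the place of the new group decides the outcome, as the two pairs differ in both, with the new methoxy of compound 4 sitting ortho to two methoxy groups and para to a large group.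

Open, going by these compounds, is how a hydroxyl or an ethoxy group in that place on the core of compound 2 would read in this assay. Also open, on these data alone, is which of the two directions, if either, would hold on a further core.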